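Fluoro for methyl on a shared core, measured once

The source may report more compounds than this note shows. Statements on the series, on what has been measured and on what is new or still open speak of the compounds shown alone.

Compound 1 `COc1ccc(Cn2cc(CO/N=C/c3c(-c4ccc(C)cc4)nc4c(C)cccn34)nn2)cc1` gives 100 mg/kg in a functional assay on the whole organism (strain NMRI) with Mus musculus as the target, with a stated time of 4 h; on this read-out higher numbers stand for an effect only at larger amounts of compound and lower numbers for an effect already at smaller amounts. Compound 2 `COc1ccc(Cn2cc(CO/N=C/c3c(-c4ccc(F)cc4)nc4c(C)cccn34)nn2)cc1` carries the change fluoro in place of methyl on an aromatic carbon and in this assay gives 40 mg/kg, so that the step of a 2.5-fold lower number from compound 1 to compound 2 (0.40 log units; beyond the scatter) is a modest one beyond the scatter. Compound 3 `Cc1ccc(-c2nc3c(C)cccn3c2/C=N/OCc2cn(Cc3ccc(C#N)cc3)nn2)cc1` differs from compound 1 by cyano in place of methoxy on an aromatic carbon; in this assay compound 3 gives 100 mg/kg, and the step of no change at the digits printed from compound 1 to compound 3 (within the scatter) lies within the scatter, so compound 1 and compound 3 stand level. Compound 4 `Cc1cccn2c(/C=N/OCc3cn(Cc4ccc(C#N)cc4)nn3)c(-c3ccc(F)cc3)nc12` has not been measured. It differs from compound 3 by fluoro in place of methyl on an aromatic carbon, the same change that was made from compound 1 to compound 2, occurring twice among the four compounds. Among the measured compounds shown here, since compound 3 and compound 1 stand level, and the only measured instance of this change gave a 2.5-fold lower number from compound 1 to compound 2 (0.40 log units; beyond the scatter), the step is expected to read about a 2.5-fold lower number from compound 3 to compound 4 (0.40 log units; beyond the scatter) in this assay. For the measured compounds named here, the estimate for compound 4 is therefore 40 mg/kg, with a likely range from 20 mg/kg to 100 mg/kg, resting on the single measured pair alone.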

Compound 4, minimum effective dose: 40 mg/kg
The estimate for compound 4 equals the measured number at the digits printed; the range from low to high includes it.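

In this assay, fluoro in place of methyl on the core carrying cyano gives a 2.5-fold lower number from compound 3 to compound 4 (0.40 log units; beyond the scatter), which matches the step on the core carrying methoxy: the same change on two cores in this assay, a 2.5-fold lower number (0.40 log units; beyond the scatter) from compound 1 to compound 2 and a 2.5-fold lower number (0.40 log units; beyond the scatter) from compound 3 to compound 4, 1.0-fold (0.00 log units) apart, within the scatter of two such steps. Cyano in place of methoxy, read on the core carrying fluoro, gives no change at the digits printed from compound 2 to compound 4 (within the scatter), which likewise matches its earlier reading: the same change on two cores in this assay, no change at the digits printed (within the scatter) from compound 1 to compound 3 and no change at the digits printed (within the scatter) from compound 2 to compound 4, 1.0-fold (0.00 log units) apart, within the scatter of two such steps. Together the two pairs show the change from 4-methylphenyl to 4-fluorophenyl carrying over between these two cores in this one read-out, but they do not show that it would carry over to a core altered anywhere else in the structure.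

On these data alone, whether a chloro group or an amine in that same place would shift the number, and whether a carboxylic acid in place of the cyano or methoxy group would leave it unchanged, remains open. Also open, as far as these compounds go, is whether the same step would hold in any other read-out.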